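The source may report more compounds than this note shows. Statements on the series, on what has been measured and on what is new or still open speak of the compounds shown alone.

Compound 1 `COc1cc(-c2cc3nccc(-c4c[nH]c5ccccc45)n3n2)cc(OC)c1OC`: > 10000 nM
Compound 2 `COc1cc(-c2ccnc3cc(-c4ccc(C)cc4)nn23)cc(OC)c1OC`: 3 nM

In a functional assay on A549 cells (Homo sapiens) for inhibition, read by CCK-8 assay, with a stated time of 48 h (a higher number here means a weaker inhibitor, a lower number a stronger inhibitor), compound 1 gives only a limit, > 10000 nM, which is the limit of > 10000 nM in this assay, at which 1 of the 2 values shown sits. Among the measured compounds shown here, compound 2 is thus the single compound with a measured number, at 3 nM. Compound 3 `COc1cc(-c2ccnc3cc(-c4ccc(N(C)C)cc4)nn23)cc(OC)c1OC` differs from compound 2 by dimethylamino in place of methyl on an aromatic carbon. For the measured compounds named here, no measured pair with such a change is available to set its size, so compound 3 is expected to stay close to compound 2 in this assay, with a step of a 1.3-fold higher number from compound 2 to compound 3 (0.12 log units; within the scatter) that is not expected to exceed the usual scatter. Compound 3 is therefore estimated at 4 nM, between 1 nM and 20 nM.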

Compound 3, half-maximal inhibitory concentration: 1100 nM
Estimate against measurement, compound 3: 280-fold (2.44 log units) below; measured number above the stated range.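

In this assay the change from 4-methylphenyl to 4-(dimethylamino)phenyl brings a 370-fold higher number from compound 2 to compound 3 (2.56 log units; beyond the scatter), which gives the first measured size for any change at this place, para to a large group. Methyl and dimethylamino are therefore far from interchangeable here, and this position is sensitive to its substituent. Nothing measured here accounts for the size of this step. On these data alone, whether the loss follows the nitrogen or the two extra carbons stays open. An amino group, an ethyl group or a methoxy group at this place could help separate them.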